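A Fluorophenyl for a Methoxyphenyl on the Shared Core

The source may hold more compounds than are shown below. What is called first, only, known or untested is meant among the compounds shown, and "the series" means these compounds.

Of the compounds shown here, three built on one shared core have been tested in a functional assay on HL-60 cells (Homo sapiens) for antiproliferative activity, read by MTT assay, with a stated time of 72 h; on this read-out higher numbers stand for weaker inhibition and lower numbers for stronger inhibition. Compound 1, `COc1ccccc1-c1ncnn1-c1cc(OC)c(OC)c(OC)c1`, stands only at a limit: in this assay compound 1 gives > 10000 nM, which is a limit and not a number. Compound 2, `COc1cc(-c2ncnn2-c2cccc(N)c2)cc(OC)c1OC`, also gives a limit, > 10000 nM. Compound 3, `COc1cc(-c2ncnn2-c2ccc(Cl)cc2Cl)cc(OC)c1OC`, likewise gives a limit, > 10000 nM. Among the measured compounds shown here, the single change among the measured compounds, 2,4-dichlorophenyl in place of 3-aminophenyl on an aromatic nitrogen, thus gives a step that the two limits leave unreadable from compound 2 to compound 3. All the evidence on measured steps comes to one point: the limit of > 10000 nM in this assay, at which 3 of the 3 values shown sit.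

Compound 4, `COc1cc(-n2ncnc2-c2cccc(F)c2)cc(OC)c1OC`, differs from compound 1 in 3-fluorophenyl in place of 2-methoxyphenyl on an aromatic carbon. For the measured compounds named here, no measured step touches this change, and the one step that exists cannot be read. With compound 1 at its limit and nothing pointing to a gain in this assay, compound 4 is expected to give 15000 nM, with a range from 3000 nM to 60000 nM, most probably again as a limit rather than a number. The step this estimate implies, a step that the limit leaves unreadable from compound 1 to compound 4, is expected to be none beyond the scatter.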

Compound 4, half-maximal inhibitory concentration: > 10000 nM
Compound 4: no number, only a limit; the forecaster's own chance of this, stated with the estimate: 75%; the middle value does not contradict the limit.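

Among the compounds shown here, compound 1 and compound 4 both stand at a limit rather than a number, so the change from 2-methoxyphenyl to 3-fluorophenyl gives no step that can be read. Which change on the shared core, if any, would give a measurable number in this assay stays open, as all the results so far fall at a single point: the limit of > 10000 nM in this assay, at which 4 of the 4 values shown sit.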